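A few compounds are considered here, and "the series" means these few. Any claim that something is new, unique, unknown or untested is made for them only; others in the source may bear on it.

Measured so far:
compound 1, `CO[C@H]1CC[C@H](CNc2cc(NCc3cnccc3C(F)(F)F)ncc2C#N)CC1`: 330 nM
compound 2, `CC1(C)[C@H](O)C[C@H]1Nc1nc(NCc2cnccc2C(F)(F)F)ncc1C#N`: 130 nM

Both compounds were tested in an assay on isolated protein for inhibition of protein kinase C theta type (Homo sapiens), read by TR-FRET, with a stated time of 2 h; a lower number here means a stronger inhibitor, a higher number a weaker inhibitor. Compound 1 gives 330 nM, the higher of the two numbers, and compound 2 gives 130 nM, a gap that lies beyond the usual scatter of this assay, so compound 2 is the stronger inhibitor of the pair.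

The next compound, compound 3, has the structure `CC1(C)[C@@H](Nc2cc(NCc3cnccc3C(F)(F)F)ncc2C#N)C[C@H]1C(N)=O`. Relative to compound 1 it carries one change: 3-carbamoyl-2,2-dimethylcyclobutyl in place of (4-methoxycyclohexyl)methyl on a nitrogen on an aromatic ring. The saturated ring shrinks from six members to four, a carbamoyl group replaces the methoxy group, and the ring now sits directly on the nitrogen rather than through a one-carbon link.

Among the measured compounds shown here, no measured pair shows the effect of this particular exchange, so the size of the step is open. A modest gain in potency is the expectation, with the estimated step from compound 1 to compound 3 in this assay being a 1.8-fold lower number from compound 1 to compound 3 (0.26 log units; within the scatter). Compound 3 is therefore expected to give about 180 nM, in a range from 50 nM to 650 nM.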

Compound 3, half-maximal inhibitory concentration: 140 nM
Compound 3: middle estimate off by 1.3-fold (0.11 log units), on the high side, within the range that was stated.
By their numbers in this assay, from the lowest: compounds 2 and 3 (each within the scatter of the next); then compound 1.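

In this assay, putting 3-carbamoyl-2,2-dimethylcyclobutyl in place of (4-methoxycyclohexyl)methyl on the nitrogen gives a 2.4-fold lower number from compound 1 to compound 3 (0.37 log units; beyond the scatter). Among the compounds shown here, this is the first step here between two compounds that differ in one place, and it shows that this position accepts a very different group of the same heavy-atom count and still gives a modest gain beyond the scatter. No measured data bear on why the number falls.

The exchange changes several things at once: the ring goes from six members to four, the one-carbon link disappears, the methoxy gives way to a carbamoyl group, and a hydrogen-bond donor enters, so the compounds shown cannot say which of these changes carries the step. They also leave open how this assay would read with a carboxylic acid or an aminomethyl group in place of the carbamoyl group, or with the methoxy group on the cyclobutyl ring or the carbamoyl group on the cyclohexylmethyl group.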